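The compounds below may be only part of what the source reports. "The series", "measured", "known", "first", "only" and "open" are said of these compounds alone.

Going by the values given here, compound 1, `Oc1ccc(NC(=S)Nc2ccc3[nH]ccc3c2)cc1`, stands as the lower of the two numbers so far in an ADME assay on isolated protein for inhibition of peroxidase (Raphanus sativus), read by fluorescence and Amplex Red, tested at 5 uM (a higher number here means a weaker effect of the compound at the concentration tested, a lower number a stronger effect), where compound 1 gives 41.5%. Among the compounds with values here, the only comparison comes from compound 2, `S=C(Nc1ccc(Br)cc1)Nc1ccc2[nH]ccc2c1`, which in this assay gives 82%, a step of a number 40.5 percentage points higher from compound 1 to compound 2 (beyond the scatter). Compound 3, `COC(=O)c1cc(NC(=S)Nc2ccc3[nH]ccc3c2)ccc1O`, keeps the hydroxy group of compound 1 and differs by methoxycarbonyl in place of hydrogen on an aromatic carbon. Within the data shown here, the one measured step concerns a different change, bromo in place of hydroxy on an aromatic carbon, and it was large; no measured step adds a group beside a retained hydroxy, so it bears on compound 3 only as a sign that changes on this ring can move the number far. The estimate for compound 3 is therefore kept near compound 1, with a step of a number 8.5 percentage points higher from compound 1 to compound 3 (within the scatter) expected, and a wide range: compound 3 is expected to give 50%, between 20% and 85%.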

Compound 3, a percentage reported as activity, at one concentration (the size of the read-out at that concentration, not a potency): 61.2%
Compound 3: middle estimate off by 11.2 percentage points, on the low side; measured number inside the range.
By their numbers in this assay, from the lowest: compound 1; then compound 3; then compound 2.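

The earlier step showed only what happens when the hydroxy group itself is replaced, whereas here that group stays and methoxycarbonyl enters on an aromatic carbon ortho to it, giving a number 19.7 percentage points higher from compound 1 to compound 3 (beyond the scatter) in this assay. This position therefore responds to substitution: with the hydroxy group retained, the added ester gives a weaker effect at the concentration tested, by a step that is modest yet beyond the scatter. No measurement shown here accounts for this rise.

The compounds shown leave open whether a carboxylic acid, an amine or a simple methyl at this same place would move the number in the same direction. They also leave open whether methoxycarbonyl would have a similar effect on a ring that lacks the hydroxy group.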